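The source may hold more compounds than are shown below. What is called first, only, known or untested is meant among the compounds shown, and "the series" means these compounds.

Measured in an ADME assay on MT4 cells (Homo sapiens) for cytotoxicity, read by MTT assay; a lower number here means that less compound is tolerated, a higher number that more compound is tolerated:

Compound 1 `Cc1ccc(C(=O)N(C(=S)OCCN2C(=O)c3ccccc3C2=O)c2ccc(Cl)cc2)cc1`: > 100000 nM (a limit)
Compound 2 `O=C1c2ccccc2C(=O)N1CCOC(=S)N(C(=O)c1ccc(F)cc1F)c1ccc(Cl)cc1`: 52000 nM
Compound 3 `O=C1c2ccccc2C(=O)N1CCOC(=S)N(C(=O)c1ccc(F)c(F)c1)c1ccc(Cl)cc1`: 52000 nM

Compound 1 gives > 100000 nM as its entry, and this is a limit, not a number. Compound 3 gives 52000 nM and stands level with compound 2 in this assay at the digits shown.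

The compound now in question is compound 4 `O=C1c2ccccc2C(=O)N1CCOC(=S)N(C(=O)c1cc(Cl)cc(Cl)c1)c1ccc(Cl)cc1`, and the structural change is 3,5-dichlorophenyl in place of 3,4-difluorophenyl on a carbonyl carbon, which puts 3,5-dichlorophenyl in place of 3,4-difluorophenyl on a carbonyl carbon. Three measured steps change the group at this same carbonyl carbon. Two of them, an at least 1.9-fold lower number from compound 1 to compound 2 (0.28 log units; that floor lies within the scatter) and an at least 1.9-fold lower number from compound 1 to compound 3 (0.28 log units; that floor lies within the scatter), are only floors because of the limit of > 100000 nM in this assay, at which 1 of the 3 values shown sits, and neither goes beyond the scatter. The third, the swap of 2,4-difluorophenyl for 3,4-difluorophenyl, gave no change at the digits printed from compound 2 to compound 3 (within the scatter) and is the closest guide. For the measured compounds named here, no measured compound carries 3,5-dichlorophenyl, so this replacement itself is untested, and the expectation remains loose. No step beyond the scatter is expected in this assay on this evidence, in either direction.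

The estimated step is a 1.3-fold lower number from compound 3 to compound 4 (0.11 log units; within the scatter).

For compound 4 the expected value is 40000 nM, with an estimated range from 15000 nM to 90000 nM.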

Compound 4, half-maximal cytotoxic concentration: 32000 nM
Compound 4: the middle estimate sits 1.3-fold (0.10 log units) above what was measured; low and high end bracket the measured number.
By their numbers in this assay, from the lowest: compounds 4, 2 and 3 (each within the scatter of the next). At a limit, above all of these: compound 1.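

In this assay, 3,5-dichlorophenyl on the carbonyl carbon gives a 1.6-fold lower number from compound 3 to compound 4 (0.21 log units; within the scatter) and a 1.6-fold lower number from compound 2 to compound 4 (0.21 log units; within the scatter), so the two chlorines leave compound 4 within the scatter of both difluorophenyl compounds. For the compounds shown here, the new information is an at least 3.1-fold lower number from compound 1 to compound 4 (0.49 log units; beyond the scatter), the first step at this position that goes beyond the scatter, with 4-methylphenyl as the group that leaves. That step is only a floor, because compound 1 stands at a limit and not at a number: the limit of > 100000 nM in this assay, at which 1 of the 4 values shown sits.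

The compounds shown leave open how far compound 1 truly lies from the other three, and whether a phenyl ring bearing a carboxylic acid or an amine, a pyridine ring or a plain alkyl chain on this carbonyl carbon would move the value in this assay beyond the scatter. As far as these compounds go, all four compounds also share the rest of the core, so the effect of any change elsewhere in the molecule remains open too.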